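Shrinking the amine ring on the shared quinoline core

The source may report more compounds than this note shows. Statements on the series, on what has been measured and on what is new or still open speak of the compounds shown alone.

Of the compounds shown here, three built on one shared core have been tested in a functional assay on HEK293 cells for activation of melanin-concentrating hormone receptor 1 (Rattus norvegicus), read by inositol phosphate accumulation; a higher number here means that more compound is needed for the effect, a lower number that less compound is needed. Compound 1 `O=C(CCc1ccc(C(F)(F)F)cc1)Nc1ccc2nc(N3CCC(c4ccccc4)C3)ccc2c1` gives 1770 nM. Compound 2 `CCN(CC)c1ccc2cc(NC(=O)CCc3ccc(C(F)(F)F)cc3)ccc2n1` gives 830 nM. Compound 3 `O=C(CCc1ccc(C(F)(F)F)cc1)Nc1ccc2nc(N3CC4CCC3CC4)ccc2c1` gives 190 nM and so stands lowest of the three numbers: the steps of a 9.3-fold lower number from compound 1 to compound 3 (0.97 log units; beyond the scatter) and a 4.4-fold lower number from compound 2 to compound 3 (0.64 log units; beyond the scatter) both run toward it and both lie beyond the scatter, while the step of a 2.1-fold lower number from compound 1 to compound 2 (0.33 log units; beyond the scatter) is smaller. Going by the values given here, in all three steps the only change is the amine attached to the core, so they bear directly on the next compound.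

Compound 4 `CC1CCCN1c1ccc2cc(NC(=O)CCc3ccc(C(F)(F)F)cc3)ccc2n1` differs from compound 3 by a group of 6 heavy atoms (5 carbon, 1 nitrogen; one five-membered non-aromatic ring with 1 hetero atom) in place of a group of 8 heavy atoms (7 carbon, 1 nitrogen; 2 six-membered non-aromatic rings with 1 hetero atom each), on an aromatic carbon. The new five-membered ring is smaller than the two fused six-membered rings it replaces, yet more ring-like than the open diethylamino of compound 2, so its number is expected to fall between those of compound 2 and compound 3 rather than improve on compound 3. Compound 4 is therefore expected to give 420 nM, within a range from 150 nM to 1200 nM. That estimate is expected to correspond to a step of a 2.2-fold higher number from compound 3 to compound 4 (0.34 log units; beyond the scatter) in this assay.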

Compound 4, half-maximal effective concentration: 270 nM
Beside the measured number, compound 4's estimate is 1.6-fold (0.19 log units) above it; the range from low to high includes it.
By their numbers in this assay, from the lowest: compounds 3 and 4 (each within the scatter of the next); then compound 2; then compound 1.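

In this assay the second ring is not needed at this position on the shared core: with a 1.4-fold higher number from compound 3 to compound 4 (0.15 log units; within the scatter) as the step, the smaller 2-methylpyrrolidin-1-yl group and the two-ring amine of compound 3 cannot be told apart. The same group also reads better than the open diethylamino, with a 3.1-fold lower number from compound 2 to compound 4 (0.49 log units; beyond the scatter) as the step, and better than the other five-membered ring amine, with a 6.6-fold lower number from compound 1 to compound 4 (0.82 log units; beyond the scatter) as the step, so having a five-membered ring does not by itself set the number; what hangs on that ring matters too. No measurement here explains why these amines differ.

The compounds shown leave open how the plain pyrrolidin-1-yl group would read, and with it whether the methyl group contributes at all. A 3-methylpyrrolidin-1-yl group would further show whether the place of the substituent on the ring or the change from phenyl to methyl separates compound 1 from compound 4.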